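Working notes: 4-fluorobenzyl in place of 2-chlorophenyl on sulfur

This account rests on a few compounds, and the source may have more. Where it says the series, first, only, none or still open, it means among the compounds named here.

Measured in a functional assay on DU-145 cells (Homo sapiens) for inhibition, read by trypan blue exclusion, with a stated time of 96 h (a lower number here means a stronger inhibitor of growth, a higher number a weaker inhibitor of growth), so far:
- compound 1 `CCOc1ccc(/C=C(/Sc2ccccc2Cl)C(=O)c2ccc(Cl)cc2)cc1OC` gives 50000 nM
- compound 2 `Cc1ccc(CS(=O)(=O)/C(=C/c2cc(C)ccc2C)C(=O)c2ccc(Cl)cc2)cc1` gives 1000 nM

Compound 1 stands highest of the two numbers, the weaker inhibitor of growth, and the gap to compound 2 lies beyond the scatter. Compound 3 `CCOc1ccc(/C=C(/SCc2ccc(F)cc2)C(=O)c2ccc(Cl)cc2)cc1OC` is still unmeasured. It departs from compound 1 by 4-fluorobenzyl in place of 2-chlorophenyl on a sulfur on a sulfur. Among the measured compounds shown here, no measured step covers this change, so the expectation rests on thin ground. A moderate downward step is expected: compound 1 at 50000 nM is the higher value, and compound 2 at 1000 nM shows that lower numbers occur. The expected change in this assay is a 5.0-fold lower number from compound 1 to compound 3 (0.70 log units; beyond the scatter) as an estimate. For compound 3 the estimated value is 10000 nM within an expected range of 2000 nM to 50000 nM overall.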

Compound 3, concentration for 50% growth inhibition: 1000 nM
Compound 3: the middle estimate sits 10-fold (1.00 log units) above what was measured; measured number outside the range, below it.
By their numbers in this assay, from the lowest: compounds 2 and 3 (each within the scatter of the next); then compound 1.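

In this assay, the group on the sulfur of the core of compound 1 strongly affects growth inhibition: 4-fluorobenzyl in place of 2-chlorophenyl gives a 50-fold lower number from compound 1 to compound 3 (1.70 log units; beyond the scatter). Among the compounds shown here, this is the first single-place comparison, and it shows that this position is sensitive to the choice of group. No available evidence bears on the origin of this step.

The compounds shown do not separate the effect of the benzyl form from that of the halogen. As far as these compounds go, whether 2-chlorobenzyl or a longer chain such as 2-phenylethyl on this sulfur behaves similarly remains open.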